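The compounds below may be only part of what the source reports. "The series", "measured", "known", "first", "only" and "open" are said of these compounds alone.

Measured in a functional assay on RAW264.7 cells (Mus musculus) for inhibition; a lower number here means a stronger inhibitor, a higher number a weaker inhibitor:
Compound 1 `CCOC(=O)C1=CCCCC1S(=O)(=O)Nc1ccc(Cl)cc1F` gives 160 nM
Compound 2 `CCOC(=O)C1=CCCCC1S(=O)(=O)Nc1ccccc1F` gives 75 nM
Compound 3 `CCOC(=O)C1=CCCCC1S(=O)(=O)Nc1ccc(F)cc1` gives 110 nM

Compound 2 (75 nM) is level with compound 3 within the scatter, and it stands clear of compound 1 by a modest step (a 2.1-fold lower number from compound 1 to compound 2 (0.33 log units; beyond the scatter)) in which hydrogen replaces chloro. Compound 4 `CCOC(=O)C1=CCCCC1S(=O)(=O)Nc1c(F)cccc1F` differs from compound 2 by one change (fluoro in place of hydrogen on an aromatic carbon), fluoro in place of hydrogen on an aromatic carbon. Going by the values given here, no measured step makes this exact change. The closest are that modest chloro step and the move of the fluoro group (a 1.5-fold higher number from compound 2 to compound 3 (0.17 log units; within the scatter)), which stays within the scatter. In this assay only a small step is therefore expected, none beyond the scatter, leaning towards a higher number. The estimated step (a 1.2-fold higher number from compound 2 to compound 4 (0.08 log units; within the scatter)) is correspondingly slight. For compound 4 the estimated value is 90 nM with an expected range from 40 nM to 200 nM on measurement.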

Compound 4, half-maximal inhibitory concentration: 160 nM
The estimate for compound 4 lay 1.8-fold (0.25 log units) below the measured number; the range from low to high includes it.
By their numbers in this assay, from the lowest: compounds 2, 3, 1 and 4 (each within the scatter of the next, the first and the last beyond it).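

Placing a second fluoro on the aromatic carbon ortho to a large group and meta to a fluoro group gives a 2.1-fold higher number from compound 2 to compound 4 (0.33 log units; beyond the scatter) in this assay. This is a real cost, not a neutral change, and it shows that this position of compound 2 does not tolerate even a single added fluorine without loss. Nothing measured here accounts for the step. As far as these compounds go, whether a methoxy or an amine on the same carbon would carry a similar cost remains open, as does whether a chloro there would.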